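Ester tail variation and half-life in human liver microsomes

A few compounds are considered here, and "the series" means these few. Any claim that something is new, unique, unknown or untested is made for them only; others in the source may bear on it.

Compound 1 `CCCOC(=O)/C=C/c1ccc(NC(=O)C2(NC(=O)c3ccc4c(C5CCCC5)c(-c5ncc(Cl)cn5)n(C)c4c3)CCC2)cc1OCC`: in an ADME assay (liver) for pharmacokinetics, with Liver microsome (Homo sapiens) as the target, using microsomes (a lower number here means that the compound disappears faster, a higher number that the compound lasts longer), compound 1 gives > 5 h, a limit of the assay.
Compound 2 `CCCCCCOC(=O)/C=C/c1ccc(NC(=O)C2(NC(=O)c3ccc4c(C5CCCC5)c(-c5ncc(Cl)cn5)n(C)c4c3)CCC2)cc1OCC`: compound 2 gives 17.9 h.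
Compound 3 `CCOc1cc(NC(=O)C2(NC(=O)c3ccc4c(C5CCCC5)c(-c5ncc(Cl)cn5)n(C)c4c3)CCC2)ccc1/C=C/C(=O)OCC(Cl)(Cl)Cl`: compound 3 gives > 5 h, again a limit.

Compound 3 stands at a limit of this assay, so no number sets it against the other two. The steps a step that the two limits leave unreadable from compound 1 to compound 3 and a step that the limit leaves unreadable from compound 2 to compound 3 end at compound 3, and a step that the limit leaves unreadable from compound 1 to compound 2 joins the remaining pair; none is readable because of the limit of > 5 h in this assay, at which 2 of the 3 values shown sit. Compound 4 `CCCN(C)C(=O)COC(=O)/C=C/c1ccc(NC(=O)C2(NC(=O)c3ccc4c(C5CCCC5)c(-c5ncc(Cl)cn5)n(C)c4c3)CCC2)cc1OCC` differs from compound 3 by methyl(propyl)carbamoyl in place of trichloromethyl on a saturated chain carbon bound to an oxygen next to a carbonyl group. Among the compounds with values here, no measured step carries a group of this kind, so the expected step that the limit leaves unreadable from compound 3 to compound 4 is drawn only from the span of the three values, with no direction beyond the scatter. Compound 4 is estimated at 8 h, between 2 h and 30 h.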

Compound 4, half-life: 0.317 h
Compound 4: the middle estimate sits 25-fold (1.40 log units) above what was measured; the whole stated range lies above it.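

Within the data shown here, on the saturated chain carbon bound to an oxygen next to a carbonyl group, methyl(propyl)carbamoyl gives the only fully readable step in this assay, a 56-fold lower number from compound 2 to compound 4 (1.75 log units; beyond the scatter). The same change also gives an at least 15-fold lower number from compound 3 to compound 4 (1.19 log units; beyond the scatter) and an at least 15-fold lower number from compound 1 to compound 4 (1.19 log units; beyond the scatter). These last two steps are bounded on one side only, because each starts at a limit: the limit of > 5 h in this assay, at which 2 of the 4 values shown sit.

The steps among compound 1, compound 2 and compound 3 still cannot be read. Open, as far as these compounds go, is whether dimethylcarbamoyl or a carboxylic acid at this place would track compound 4 or compound 2.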